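Replacing the pyridyl amide of compound 3 with a chlorophenyl

The compounds below may be only part of what the source reports. "The series", "measured", "known", "first", "only" and "open" are said of these compounds alone.

Measured in an assay on C3H 10T1/2 cells for inhibition of Sonic hedgehog protein (Mus musculus), read by a luciferase reporter; a lower number here means a stronger inhibitor, a higher number a weaker inhibitor:
compound 1, `Cc1nc(C(F)(F)F)ccc1C(=O)Nc1ccc(Cl)c(-c2cnccn2)c1`, gives 1700 nM
compound 2, `Cc1ccc(C(=O)Nc2ccc(Cl)c(-c3ccccn3)c2)c(C)n1`, gives 130 nM
compound 3, `O=C(Nc1ccc(Cl)c(-c2ccccn2)c1)c1ccncc1`, gives 700 nM

Compound 3 holds the second highest number of the three. Compound 2 lies below it, by the step of a 5.4-fold higher number from compound 2 to compound 3 (0.73 log units; beyond the scatter), and compound 1 lies above it, a gap that is also beyond the scatter. Among the compounds with values here, compound 1 differs from the others in more than one place, so no single step can be drawn from it.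

Compound 4, `O=C(Nc1ccc(Cl)c(-c2ccccn2)c1)c1cccc(Cl)c1`, is the next compound in this series. It differs from compound 3 by 3-chlorophenyl in place of pyridin-4-yl on a carbonyl carbon. Within the data shown here, the only measured step that touches the same position is the one from compound 2 to compound 3, where exchanging the group on the carbonyl carbon moved the number by a 5.4-fold higher number from compound 2 to compound 3 (0.73 log units; beyond the scatter), a modest shift. Among the measured compounds shown here, that step shows the position is sensitive, but no measured compound carries a ring of carbon only at this place, so the direction for compound 4 rests on little. A shift of comparable size in either direction is plausible; a small move toward a lower number is expected for compound 4, amounting to a 1.8-fold lower number from compound 3 to compound 4 (0.24 log units; within the scatter) in this assay. Compound 4 is estimated at 400 nM, with a range from 120 nM to 1400 nM.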

Compound 4, half-maximal inhibitory concentration: 1500 nM
The estimate for compound 4 lay 3.8-fold (0.57 log units) below the measured number, and the stated range ends below it.
By their numbers in this assay, from the lowest: compound 2; then compound 3; then compounds 4 and 1 (each within the scatter of the next).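

In this assay, the step of a 2.1-fold higher number from compound 3 to compound 4 (0.33 log units; beyond the scatter) shows that a ring of carbon only, here 3-chlorophenyl, does not lower the number from that of the pyridin-4-yl it replaces on the carbonyl carbon. Set against the 2,6-dimethylpyridin-3-yl group, the same ring gives a 12-fold higher number from compound 2 to compound 4 (1.06 log units; beyond the scatter) and so widens the range seen at this place, with 2,6-dimethylpyridin-3-yl holding the lowest number of the three groups and 3-chlorophenyl the highest, each gap beyond the scatter. Nothing among the data shown explains why the number moves this way.

The exchange from compound 3 to compound 4 removes the ring nitrogen and adds the chlorine in one step, so the share of each in the change cannot be told apart. Going by these compounds, what an unsubstituted phenyl would give at this place stays open, and so does whether a single methyl on a pyridine ring would keep part of the low number of compound 2.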